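This account rests on a few compounds, and the source may have more. Where it says the series, first, only, none or still open, it means among the compounds named here.

In a functional assay on cells (Cancer cell lines, Homo sapiens) for inhibition (a lower number here means a stronger inhibitor of growth, a higher number a weaker inhibitor of growth), compound 1 (`N=C(N)N/N=C/c1c(-c2cc(Cl)sc2Cl)nc2n1CCS2`) gives 22900 nM, compound 2 (`N=C(N)N/N=C/c1c(-c2ccsc2)nc2sccn12`) gives 31600 nM and compound 3 (`Cc1cc(-c2nc3n(c2/C=N/NC(=N)N)CCS3)c(C)s1`) gives 41700 nM. Compound 3 therefore stands within the scatter of both other compounds, and the numbers separate none of the three. Compound 4 (`N=C(N)N/N=C/c1c(-c2cccs2)nc2n1CCS2`) keeps the core of compound 3 and differs in one place, with thiophen-2-yl in place of 2,5-dimethylthiophen-3-yl on an aromatic carbon. Within the data shown here, only one measured step bears directly on this change. It is a 1.8-fold higher number from compound 1 to compound 3 (0.26 log units; within the scatter), which swaps the substituents on the thiophene over the same core and stays within the scatter. Compound 2 also carries a thiophene without substituents, but on a different core, so its 31600 nM offers only loose support. Among the measured compounds shown here, no measured step covers the move of the thiophene attachment or the loss of its substituents. A step beyond the scatter is therefore not expected in this assay. The expected step is a 1.3-fold lower number from compound 3 to compound 4 (0.11 log units; within the scatter). Compound 4 is estimated at 32000 nM, within an expected range of 16000 nM to 63000 nM.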

Compound 4, concentration for total growth inhibition: 40700 nM
Compound 4: the middle estimate sits 1.3-fold (0.10 log units) below what was measured; measured number inside the range.
By their numbers in this assay, from the lowest: compounds 1, 2, 4 and 3 (each within the scatter of the next).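

In this assay, the step of a 1.0-fold lower number from compound 3 to compound 4 (0.01 log units; within the scatter) shows that this position, on an aromatic carbon next to the ring nitrogen, tolerates more than a swap of substituents on the thiophene: thiophen-2-yl stands level with 2,5-dimethylthiophen-3-yl, although both the attachment point and the substituents differ. The step of a 1.8-fold higher number from compound 1 to compound 4 (0.25 log units; within the scatter) likewise stays within the scatter, so the three thiophenes on the shared core are not separated by this read-out. No evidence is available to explain this lack of separation.

The compounds shown do not tell the change of attachment point apart from the loss of the substituents, since both occur together in this step. They also leave open whether a group other than a thiophene at this position, such as an amine or a carboxylic acid, would give a step beyond the scatter.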